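From Ethyl to Isopropyl on a Shared Core

The source may hold more compounds than are shown below. What is called first, only, known or untested is meant among the compounds shown, and "the series" means these compounds.

Of the compounds shown here, two have been measured so far. Compound 1 `Cc1n[nH]c(C(=O)O)c1Cc1cccc(-c2ccc(C#N)cc2)c1` gives 300 nM in an assay on isolated protein for inhibition of 2-Hydroxyacid oxidase 2 (Rattus norvegicus); on this read-out higher numbers stand for weaker inhibition and lower numbers for stronger inhibition. Compound 2 `CCc1n[nH]c(C(=O)O)c1Cc1cccc(-c2ccc(F)cc2)c1` gives 300 nM in this assay. Compound 2 thus stands level with compound 1 at the digits shown; because the two differ in more than one place, no single step between them can be read off, and their values simply show two compounds with matching numbers.

Compound 3 `CC(C)c1n[nH]c(C(=O)O)c1Cc1cccc(-c2ccc(F)cc2)c1` has not yet been measured. It differs from compound 2 in one place: methyl in place of hydrogen on a saturated chain carbon bound to an aromatic carbon and a saturated chain carbon. Within the data shown here, nothing among the measured compounds shows what such a change does here, as the only pair at hand differs elsewhere as well. Among the measured compounds shown here, with no step to lean on, the expected size of the change in this assay is none beyond the scatter, in either direction. Compound 3 is accordingly estimated at 300 nM, with a range from 100 nM to 1000 nM. The step this estimate means, no change at the digits printed from compound 2 to compound 3 (within the scatter), is an expectation and not a measurement.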

Compound 3, half-maximal inhibitory concentration: 500 nM
Estimate against measurement, compound 3: 1.7-fold (0.22 log units) below; the range from low to high includes it.
By their numbers in this assay, from the lowest: compounds 1, 2 and 3 (each within the scatter of the next).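

Among these compounds, this is the only comparison so far in which a single place differs: with the rest of the molecule held the same, going from ethyl to isopropyl gives a 1.7-fold higher number from compound 2 to compound 3 (0.22 log units; within the scatter) in this assay. That step lies within the usual scatter of repeated measurements, so compound 2 and compound 3 cannot be told apart on this read-out, and on this saturated chain carbon bound to an aromatic carbon and a saturated chain carbon, the extra methyl makes no difference that the assay can resolve. No measurement on these compounds offers an explanation for this result.

The compounds shown leave open whether this tolerance reaches further, for instance to a tert-butyl group, a longer chain such as butyl, or a chain ending in an amine. The separate contributions of the nitrile in compound 1 and the fluorine in compound 2 also cannot be read, as those two compounds differ in more than one place.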